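The source may hold more compounds than are shown below. What is called first, only, known or untested is meant among the compounds shown, and "the series" means these compounds.

Compound 1 `COc1cc(N)c(Cl)cc1NC(=O)C1CCN(CC2CCC2)CC1` carries a cyclobutyl on a saturated chain carbon bound to an amine nitrogen in a ring. In a functional assay on the whole organism for antagonist activity, with Mus musculus as the target (a lower number here means that less compound is needed, a higher number that more compound is needed for the effect), compound 1 reaches only a limit, > 10 mg/kg. For the measured compounds named here, compound 2 `CCOc1ccc(CN2CCC(C(=O)Nc3cc(Cl)c(N)cc3OC)CC2)cc1` has a 4-ethoxyphenyl at that place, and in this assay compound 2 gives 6.3 mg/kg, the only number among the three values shown. Compound 3 `COc1cc(N)c(Cl)cc1NC(=O)C1CCN(Cc2ccc(C)c(C)c2)CC1` carries a 3,4-dimethylphenyl there; in this assay compound 3 reaches a limit, > 8 mg/kg. The measured steps are an at least 1.5-fold lower number from compound 1 to compound 2 (0.20 log units; that floor lies within the scatter) and an at least 1.2-fold higher number from compound 2 to compound 3 (0.10 log units; that floor lies within the scatter), while a step that the two limits leave unreadable from compound 1 to compound 3.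

Compound 4 `COc1cc(N)c(Cl)cc1NC(=O)C1CCN(Cc2cccc(Cl)c2)CC1` differs from compound 2 by 3-chlorophenyl in place of 4-ethoxyphenyl on a saturated chain carbon bound to an amine nitrogen in a ring. The step that bears on it is an at least 1.2-fold higher number from compound 2 to compound 3 (0.10 log units; that floor lies within the scatter), also a swap of one aromatic ring for another at this place, and it ended in a limit rather than a number. A higher number is therefore expected for compound 4, of a size the data leave open. The expected value of compound 4 is 9 mg/kg, within a range from 3 mg/kg to 25 mg/kg. That expectation amounts to a 1.4-fold higher number from compound 2 to compound 4 (0.15 log units; within the scatter).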

Compound 4, dose for half-maximal effect: > 4 mg/kg
Compound 4 was reported as a limit (the forecaster's own chance of this, stated with the estimate: 50%); the middle value does not contradict the limit.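

In this assay compound 4 reaches only a limit, > 4 mg/kg, so its steps to compound 1, compound 2 and compound 3 cannot be read. As far as these compounds go, whether compound 4 needs more or less compound than compound 2 stays open, as does any ranking of the four groups at this place.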